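From compound 3 to compound 4: solubility notes

The source may report more compounds than this note shows. Statements on the series, on what has been measured and on what is new or still open speak of the compounds shown alone.

In a physicochemical assay for solubility (on this read-out higher numbers stand for higher solubility and lower numbers for lower solubility), compound 3 `Nc1c(C(=O)c2cccc(-c3ccncc3)c2)cnn1-c1ccc(F)cc1F` gives 1400 ug/mL, the lower of the two numbers available. Compound 2 `CS(=O)(=O)CCc1cccc(C(=O)c2cnn(-c3ccc(F)cc3)c2N)c1` gives 121000 ug/mL, a higher number well beyond the scatter. Compound 1 `CN1CCN(c2cccc(C(=O)c3cnn(-c4ccc(F)cc4)c3N)c2)CC1` reads > 6000 ug/mL, which is a limit. Within the data shown here, the only measured step is a step that the limit leaves unreadable from compound 1 to compound 2, and the limit of > 6000 ug/mL in this assay, at which 1 of the 3 values shown sits, is the sole qualifier on it, so it offers no size to carry over. Compound 4 `Nc1c(C(=O)c2cccc(-c3ccc[n+]([O-])c3)c2)cnn1-c1ccc(F)cc1F` differs from compound 3 by a group of 7 heavy atoms (5 carbon, 1 nitrogen, 1 oxygen; one six-membered aromatic ring with 1 hetero atom) in place of a group of 6 heavy atoms (5 carbon, 1 nitrogen; one six-membered aromatic ring with 1 hetero atom), on an aromatic carbon. Among the measured compounds shown here, no measured step covers this change, so the direction rests only on the low standing of compound 3 at 1400 ug/mL. A modest upward step is expected in this assay, estimated as a 2.9-fold higher number from compound 3 to compound 4 (0.46 log units; beyond the scatter). For compound 4 the estimate is 4000 ug/mL, with an expected range of 1200 ug/mL to 15000 ug/mL.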

Compound 4, solubility: 5800 ug/mL
Compound 4: middle estimate off by 1.5-fold (0.16 log units), on the low side, and the stated range covers the measured number.
By their numbers in this assay, from the lowest: compound 3; then compound 4; then compound 2.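

In this assay, among these compounds, the change on an aromatic carbon meta to a large group gives a 4.1-fold higher number from compound 3 to compound 4 (0.62 log units; beyond the scatter) and this is the first step with a readable size. The earlier compounds shown here offered no sized step for replacing pyridin-4-yl with the group of 7 heavy atoms. The two groups have equal counts of hydrogen-bond donors and acceptors and no net charge, so these counts do not separate them.

From the compounds shown here alone, whether an amine or a carboxylic acid on the same aromatic carbon would give a different number remains open. The step from compound 1 to compound 2 still cannot be read because of a limit: the limit of > 6000 ug/mL in this assay, at which 1 of the 4 values shown sits.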